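The compounds below may be only part of what the source reports. "The series", "measured", "known", "first", "only" and "open" are said of these compounds alone.

Measured so far:
compound 1, `CCCN(C(=O)CC(=O)O)C1=C(C)CC(c2ccccc2)N(CCCCN)C1=O` — 43 nM
compound 3, `CCCN(C(=O)CC(=O)O)C1=C(C)CC(c2ccccc2)N(Cc2ccc(N)cc2)C1=O` — 170 nM
compound 2, `CCCN(C(=O)C(CC(=O)OC)C(=O)O)C1=C(C)CC(c2ccccc2)N(Cc2ccc(N)cc2)C1=O` — > 1000000 nM (a limit of the assay, not a number)

In an assay on K562 cells for inhibition of integrin alpha-5/beta-1 (Homo sapiens) (a higher number here means a weaker inhibitor, a lower number a stronger inhibitor), compound 3 gives 170 nM, the highest of the two numbers shown; its nearest neighbour is compound 1, which gives 43 nM, and the step of a 4.0-fold higher number from compound 1 to compound 3 (0.60 log units; beyond the scatter) lies beyond the scatter. Compound 2 reaches only the limit of > 1000000 nM in this assay; the step of an at least 5800-fold lower number from compound 2 to compound 3 (3.76 log units; beyond the scatter) is therefore a lower bound on the change.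

Compound 4, `CCCN(C(=O)C(CC(=O)O)C(=O)O)C1=C(C)CC(c2ccccc2)N(Cc2ccc(N)cc2)C1=O`, differs from compound 3 by carboxymethyl in place of hydrogen on a saturated chain carbon bound to two carbonyl carbons. Among the compounds with values here, the only measured step at the same place is the one from compound 2, where the (methoxycarbonyl)methyl group sat at that carbon and the value reached the limit (the limit of > 1000000 nM in this assay, at which 1 of the 3 values shown sits). Carboxymethyl is that group without its methyl ester, so compound 4 is expected to lose much of the potency of compound 3, a step of a 120-fold higher number from compound 3 to compound 4 (2.07 log units; beyond the scatter) in the direction of a higher number in this assay, though likely smaller than the step to compound 2. Compound 4 is thus estimated at 20000 nM, between 500 nM and 1000000 nM.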

Compound 4, half-maximal inhibitory concentration: > 1000000 nM
Compound 4 ended at the assay's limit (the forecaster's own chance of this, stated with the estimate: 30%); middle value at least 50-fold (1.69 log units) from the limit.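

In this assay, carboxymethyl on the saturated chain carbon bound to two carbonyl carbons gives a loss as large as can be read: an at least 5800-fold higher number from compound 3 to compound 4 (3.76 log units; beyond the scatter). Compound 4 sits at a limit of the assay, so this step is only a lower bound, and the earlier compounds had shown such a loss only with the (methoxycarbonyl)methyl group of compound 2. The free acid therefore shows no recovery from the ester, although the step between compound 2 and compound 4 cannot be read, as both stand at the limit: the limit of > 1000000 nM in this assay, at which 2 of the 4 values shown sit.

The compounds shown leave open whether a methyl or hydroxyl group on that carbon would keep the potency of compound 3. They also leave open whether carboxymethyl costs as much on the core of compound 1.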